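A few compounds are considered here, and "the series" means these few. Any claim that something is new, unique, unknown or untested is made for them only; others in the source may bear on it.

In a functional assay on MDA-MB-231 cells (Homo sapiens) for cytotoxicity, read by sulforhodamine B assay, with a stated time of 3 days (a higher number here means that more compound is needed for the effect, a lower number that less compound is needed), compound 1 (`CCOCc1c(C)coc1-c1ccc2c(c1OC)CCCC2(C)C`) gives 42.7 uM and sits within the scatter of both other measured compounds. Compound 2 (`Cc1coc(-c2ccc3c(c2O)CCCC3)c1C(=O)O`) gives 73.5 uM and compound 3 (`Cc1coc(-c2ccc3c(c2O)CCCC3(C)C)c1C(=O)O`) gives 24.7 uM in the same test.

Among the measured compounds shown here, no two of these three differ in one place only, so no measured step bears directly on the next change. Compound 4 (`COc1c(-c2occ(C)c2COC(C)=O)ccc2c1CCCC2(C)C`) keeps the core of compound 1 and carries acetyl in place of ethyl on an oxygen on a saturated carbon, which turns ethoxymethyl into acetoxymethyl.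

For the measured compounds named here, with no measured precedent for this change, no shift beyond the scatter is expected in this assay and no direction is favoured. The expectation therefore starts from compound 1 at 42.7 uM and stays close to it. The estimated step of a 1.1-fold lower number from compound 1 to compound 4 (0.05 log units; within the scatter) is small. Compound 4 is estimated at 38 uM with an expected range from 16 uM to 85 uM in this test.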

Compound 4, concentration for half-maximal effect: 55.6 uM
Compound 4: the middle estimate sits 1.5-fold (0.17 log units) below what was measured; low and high end bracket the measured number.
By their numbers in this assay, from the lowest: compounds 3, 1, 4 and 2 (each within the scatter of the next, the first and the last beyond it).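

On the oxygen on a saturated carbon, acetyl in place of ethyl gives a 1.3-fold higher number from compound 1 to compound 4 (0.11 log units; within the scatter) in this assay, and this one-place step lies within the scatter. This position therefore takes ethoxymethyl or acetoxymethyl with no shift that can be told from the scatter, even though acetyl brings a carbonyl and one more hydrogen-bond acceptor. Nothing available explains this outcome.

As far as these compounds go, one step at one position sets no trend, so it remains open whether a longer chain such as butyryl, a benzoyl or an amine-bearing chain on the same oxygen would also stay within the scatter. From the compounds shown here alone, compound 2 and compound 3 differ from compound 1 and compound 4 in more than one place, so the effect of the other parts of the structure also remains open.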